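From nitro to amino in a small series

This account rests on a few compounds, and the source may have more. Where it says the series, first, only, none or still open, it means among the compounds named here.

In a functional assay on MCF7 cells (Homo sapiens) for cytotoxicity, read by MTT assay, with a stated time of 48 h (on this read-out higher numbers stand for weaker inhibition of growth and lower numbers for stronger inhibition of growth), compound 1 (`Cn1c(C(F)(F)F)nc2cc(Cl)c(Cl)cc21`) gives 39000 nM and compound 2 (`C=CCn1c(C(F)(F)F)nc2cc(Cl)c(Cl)cc21`) gives 87000 nM. Compound 3 (`O=[N+]([O-])c1ccccc1Cn1c(C(F)(F)F)nc2cc(Cl)c(Cl)cc21`) gives 1500 nM, the lowest of the three numbers. The next structure is compound 4 (`Nc1ccccc1Cn1c(C(F)(F)F)nc2cc(Cl)c(Cl)cc21`), which differs from compound 3 as follows: amino in place of nitro on an aromatic carbon. This places amino in place of nitro on an aromatic carbon.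

Going by the values given here, the only measured step is a 2.2-fold higher number from compound 1 to compound 2 (0.35 log units; beyond the scatter), modest in size and made on the chain at the aromatic nitrogen. It therefore bears only weakly on a change at an aromatic carbon. Among the compounds with values here, no measured pair changes nitro, and no measured compound carries amino. Loss of the nitro group is nevertheless expected to move the number part of the way toward that of compound 1 at 39000 nM. The estimated step in this assay is a 4.0-fold higher number from compound 3 to compound 4 (0.60 log units; beyond the scatter), with wide uncertainty. For compound 4 the expected value is 6000 nM, with an estimated range from 1500 nM to 30000 nM.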

Compound 4, concentration for 50% growth inhibition: 55600 nM
Beside the measured number, compound 4's estimate is 9.3-fold (0.97 log units) below it, outside the stated range (above it).
By their numbers in this assay, from the lowest: compound 3; then compounds 1, 4 and 2 (each within the scatter of the next, the first and the last beyond it).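

In this assay, a 37-fold higher number from compound 3 to compound 4 (1.57 log units; beyond the scatter), so on this aromatic carbon, ortho to a large group, the low number of compound 3 does not survive the change from nitro to amino. With amino in this place, the 2-aminophenyl group leaves the number level with those of the two smaller substituents on the same nitrogen: a 1.4-fold higher number from compound 1 to compound 4 (0.15 log units; within the scatter), and a 1.6-fold lower number from compound 2 to compound 4 (0.19 log units; within the scatter). Nothing available accounts for the size of the nitro to amino step.

Still open, on these data alone, is whether a nitrile or a carboxylic acid on this carbon would keep the number near that of compound 3, which gives 1500 nM. Also open, as far as these compounds go, is where a plain phenyl with hydrogen on this carbon would fall, and so whether nitro lowers the number or amino cancels a gain from the ring.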